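This account rests on a few compounds, and the source may have more. Where it says the series, first, only, none or still open, it means among the compounds named here.

Series notes. Compound 1 `COc1ccc(CNC(=O)CSc2nc3ccc(NC(=O)c4ccccc4OC)cc3s2)cc1` gives 2100 nM in a functional assay on HepG2 cells (Homo sapiens) for cytotoxicity, read by MTT assay, with a stated time of 48 h; on this read-out lower numbers stand for stronger inhibition and higher numbers for weaker inhibition. Compound 2 `CC(=O)Nc1ccc2nc(SCC(=O)NCc3ccccc3)sc2c1` gives 9200 nM in this assay, the highest of the two numbers shown; its nearest neighbour is compound 1 at a lower number, and that gap lies beyond the scatter. Compound 3 `CNC(=O)CSc1nc2ccc(NC(=O)c3ccc([N+](=O)[O-])cc3)cc2s1` returns only a limit of the assay, > 100000 nM. Compound 4 `O=C(CSc1nc2ccc(NC(=O)c3ccccc3)cc2s1)NCc1ccccc1` is not yet measured. It differs from compound 2 in one place: phenyl in place of methyl on a carbonyl carbon. No single-change step between measured compounds is shown, so the size of this step is not fixed by data. Compound 1, which also carries a benzoyl group on the anilide nitrogen, gives 2100 nM. A modest move toward a lower number is expected, a 2.3-fold lower number from compound 2 to compound 4 (0.36 log units; beyond the scatter). Compound 4 is estimated at 4000 nM, between 1000 nM and 20000 nM.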

Compound 4, half-maximal inhibitory concentration: 34200 nM
The estimate for compound 4 lay 8.6-fold (0.93 log units) below the measured number; the measured number lies above the stated range.
By their numbers in this assay, from the lowest: compound 1; then compound 2; then compound 4. At a limit, above all of these: compound 3.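

In this assay, phenyl in place of methyl on a carbonyl carbon gives a 3.7-fold higher number from compound 2 to compound 4 (0.57 log units; beyond the scatter), the only single-change step shown, so this position now has a measured response. Acetamido to benzamido, taken alone, moves the number up rather than down. No measurement shown gives a cause for this step. Still open, on these data alone, is how this position responds to a group other than methyl or phenyl, such as an amine or a longer chain. As far as these compounds go, whether the same step holds with a different group on the amide nitrogen at the far end of the thioacetamide chain also remains open.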